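A Longer Chain on a Compound at the Limit

The source may report more compounds than this note shows. Statements on the series, on what has been measured and on what is new or still open speak of the compounds shown alone.

In a functional assay on HeLa cells (Homo sapiens) for antiproliferative activity, read by MTT assay, with a stated time of 48 h (a lower number here means a stronger inhibitor, a higher number a weaker inhibitor), compound 1 `CN(C)CCn1c(N)c(-c2nc3ccccc3[nH]2)c2nc(C#N)c(C#N)nc21` gives 8880 nM and compound 2 `N#Cc1nc2c(-c3nc4ccccc4[nH]3)c(N)n(CCCNc3ccccc3)c2nc1C#N` gives 26300 nM as its measured value. Compound 3 `CN(C)CCn1c(N)c(-c2nc3ccccc3n2C)c2nc(C#N)c(C#N)nc21` gives > 50000 nM as its reading, which is a limit of the assay and not a number.

Compound 4 `CCN(CC)CCCn1c(N)c(-c2nc3ccccc3n2C)c2nc(C#N)c(C#N)nc21` keeps the methyl on the aromatic nitrogen of compound 3 and changes only the chain, where 2-(dimethylamino)ethyl becomes 3-(diethylamino)propyl: (diethylamino)methyl in place of dimethylamino on a saturated chain carbon, two bonds along the chain from an aromatic nitrogen is the whole difference.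

The closest measured change at this chain carbon gave a 3.0-fold higher number from compound 1 to compound 2 (0.47 log units; beyond the scatter) and shows that a swap there can shift the reading modestly. The methyl step gave an at least 5.6-fold higher number from compound 1 to compound 3 (0.75 log units; beyond the scatter) and is already built into both compound 3 and compound 4. A modest step is therefore expected in this assay but its direction cannot be read from a limit. For compound 4 the expected step is a number no higher from compound 3 to compound 4 (the limit leaves the size open) by this estimate. Compound 4 is estimated at 50000 nM with an expected range from 20000 nM to 100000 nM. For compound 4 a limit rather than a number may well be the outcome.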

Compound 4, half-maximal inhibitory concentration: 12400 nM
Compound 4: the middle estimate sits 4.0-fold (0.61 log units) above what was measured, outside the stated range (below it).
By their numbers in this assay, from the lowest: compounds 1 and 4 (each within the scatter of the next); then compound 2. At a limit, above all of these: compound 3.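

In this assay, this chain position can bring a compound back from the limit: with the methyl on the aromatic nitrogen kept, 3-(diethylamino)propyl in place of 2-(dimethylamino)ethyl gives an at least 4.0-fold lower number from compound 3 to compound 4 (0.60 log units; beyond the scatter). The earlier step at this chain carbon, a 3.0-fold higher number from compound 1 to compound 2 (0.47 log units; beyond the scatter), went the other way, so swaps here can move the number in either direction, although the two steps involve different chains and start from different compounds. The new step has no exact size, because the reading for compound 3 is a limit of the assay and not a number: the limit of > 50000 nM in this assay, at which 1 of the 4 values shown sits.

The longer chain and the ethyl groups on the amine changed together, and the compounds shown do not separate them. A 3-(dimethylamino)propyl or 2-(diethylamino)ethyl chain on the core of compound 3 would pull the two apart, and 3-(diethylamino)propyl on the core of compound 1 would test the chain with hydrogen on the aromatic nitrogen.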